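Replacing a methoxy with a pyrazolylmethyl on the core

A few compounds are considered here, and "the series" means these few. Any claim that something is new, unique, unknown or untested is made for them only; others in the source may bear on it.

Of the compounds shown here, three sharing one core have been measured in a functional assay on CHO cells for agonist activity at Melanocortin receptor 4 (Homo sapiens), read by a luciferase reporter, with a stated time of 4 h; on this read-out lower numbers stand for an effect already at smaller amounts and higher numbers for an effect only at larger amounts of compound. Compound 1 `CC(C)N(C(=O)CN1C=CN(c2ccccc2)C(=O)C(Cc2n[nH]c3ccccc23)C1=O)c1ccc(OC(F)(F)F)cc1` gives 151 nM, compound 2 `COc1ccc(N(C(=O)CN2C=CN(c3ccccc3)C(=O)C(Cc3n[nH]c4ccccc34)(OC)C2=O)C(C)C)cc1` gives 166 nM, and compound 3 `COC1(Cc2n[nH]c3ccccc23)C(=O)N(CC(=O)N(c2ccc(F)cc2)C(C)C)C=CN(c2ccccc2)C1=O` gives 44.7 nM. Compound 2 thus has the highest number of the three; its gap to compound 1 lies within the scatter, while the step of a 3.7-fold lower number from compound 2 to compound 3 (0.57 log units; beyond the scatter) lies beyond it.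

Compound 4 `COc1ccc(N(C(=O)CN2C=CN(c3ccccc3)C(=O)C(Cc3cc[nH]n3)(Cc3n[nH]c4ccccc34)C2=O)C(C)C)cc1` is made from compound 2 by a change at a different place: (1H-pyrazol-3-yl)methyl in place of methoxy on a saturated ring carbon. For the measured compounds named here, the only measured step, from compound 2 to compound 3, concerns a swap on an aromatic carbon and so gives no direct guidance on a large new group on the saturated ring carbon. Compound 1 and compound 2 differ in more than one place, so their near-equal numbers say little about this spot either. Going by the values given here, with no comparable step available, the expected step of a 1.5-fold higher number from compound 2 to compound 4 (0.18 log units; within the scatter) in this assay is small and uncertain, leaning toward a slightly higher number. Compound 4 is estimated at 250 nM, with a range from 80 nM to 800 nM.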

Compound 4, half-maximal effective concentration: 1050 nM
For compound 4 the middle estimate is 4.2-fold (0.62 log units) below the measured one; the measured number lies above the stated range.
By their numbers in this assay, from the lowest: compound 3; then compounds 1 and 2 (each within the scatter of the next); then compound 4.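

The saturated ring carbon of the seven-membered ring is not indifferent to what it carries: (1H-pyrazol-3-yl)methyl in place of methoxy gives a 6.3-fold higher number from compound 2 to compound 4 (0.80 log units; beyond the scatter) and so calls for a larger amount of compound to reach the effect. For the compounds shown here, this is the first measured single-place step at this carbon, as the earlier one concerned an aromatic carbon. The entering group brings more heavy atoms, a five-membered aromatic ring and a hydrogen-bond donor all at once, and no supporting data point to which of these matters.

A benzyl group would keep a ring without the ring nitrogens, while an ethyl group would test a small carbon chain, so the compounds shown cannot separate these features. As far as these compounds go, whether the step would be similar with the fluoro group of compound 3 also remains open.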